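This account rests on a few compounds, and the source may have more. Where it says the series, first, only, none or still open, it means among the compounds named here.

Measured so far in a physicochemical assay for solubility, read by nephelometry, in phosphate buffer; on this read-out higher numbers stand for higher solubility and lower numbers for lower solubility:
compound 1 `Cc1cc(O)ccc1NC(=O)c1cc(N(CC2CC2)C2CCCCC2)ncn1` — 8 ug/mL
compound 2 `Cc1cc2[nH]ncc2cc1NC(=O)c1cc(N(CC2CC2)C2CCCCC2)ncn1` — 5 ug/mL
compound 3 `O=C(O)CCNCc1ccc(NC(=O)c2cc(N(CC3CC3)C3CCCCC3)ncn2)cc1` — > 45 ug/mL, a limit of the assay

Compound 1 gives 8 ug/mL and stands highest of the two numbers. Among the measured compounds shown here, compound 2 gives 5 ug/mL; the only measured step, a 1.6-fold lower number from compound 1 to compound 2 (0.20 log units; within the scatter), lies within the scatter. For compound 3, this assay reports only a limit, > 45 ug/mL. Compound 4 `Cc1cc(CN2CC(C(=O)O)C2)ccc1NC(=O)c1cc(N(CC2CC2)C2CCCCC2)ncn1` differs from compound 1 by (3-carboxyazetidin-1-yl)methyl in place of hydroxy on an aromatic carbon, meta to a methyl group and para to a large group. For the measured compounds named here, no measured step exchanges a hydroxy group for such a chain; the guides are the limit compound 3 reaches, (the limit of > 45 ug/mL in this assay, at which 1 of the 3 values shown sits), and the unremarkable step from compound 1 to compound 2. Compound 4 is therefore expected to rise in solubility by a 7.5-fold higher number from compound 1 to compound 4 (0.88 log units; beyond the scatter), with a fair chance that only a limit is reported. The estimate for compound 4 is 60 ug/mL, between 20 ug/mL and 150 ug/mL.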

Compound 4, solubility: 22 ug/mL
For compound 4 the middle estimate is 2.7-fold (0.44 log units) above the measured one; measured number inside the range.
By their numbers in this assay, from the lowest: compounds 2 and 1 (each within the scatter of the next); then compound 4. At a limit, above all of these: compound 3.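

Placing (3-carboxyazetidin-1-yl)methyl in place of hydroxy, on the aromatic carbon meta to a methyl group and para to a large group, gives a 2.8-fold higher number from compound 1 to compound 4 (0.44 log units; beyond the scatter), the first step shown beyond the scatter in this assay. Compound 4 gives a readable number, 22 ug/mL, and not a limit. Compound 3 alone remains a limit of the assay: the limit of > 45 ug/mL in this assay, at which 1 of the 4 values shown sits.

The compounds shown leave open which part of the new group carries the step. A simple amine without the carboxylic acid, or a longer chain between the aromatic ring and the acid, could separate these parts.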